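Amide Replaces Urea on the Aniline Arm

The compounds below may be only part of what the source reports. "The series", "measured", "known", "first", "only" and "open" are said of these compounds alone.

Compound 1, `COc1cc(-c2nn(-c3cccc(NC(=O)c4cccc(C(F)(F)F)c4)c3)cc2-c2ccncc2)ccc1Cl`, gives 1640 nM in a functional assay on COLO 205 cells (Homo sapiens) for inhibition, read by sulforhodamine B assay, with a stated time of 48 h; a lower number here means a stronger inhibitor of growth, a higher number a weaker inhibitor of growth.
Compound 2, `COc1cc(-c2nn(-c3cccc(NC(=O)Nc4ccc(Cl)c(Cl)c4)c3)cc2-c2ccncc2)ccc1Cl`, gives 937 nM in this assay.
Compound 3, `COc1cc(-c2nn(-c3cccc(NC(=O)Nc4cccc(C(F)(F)F)c4)c3)cc2-c2ccncc2)ccc1Cl`, gives 894 nM in this assay.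

Compound 3 holds the lowest of the three numbers, yet both compound 2 and compound 1 lie within the scatter of it, so no order among the three can be claimed. Compound 4, `COc1cc(-c2nn(-c3cccc(NC(=O)c4ccc(Cl)c(C(F)(F)F)c4)c3)cc2-c2ccncc2)ccc1Cl`, differs from compound 3 by 4-chloro-3-(trifluoromethyl)phenyl in place of (3-(trifluoromethyl)phenyl)amino on a carbonyl carbon. Going by the values given here, two measured steps bear on this change. The step of a 1.8-fold lower number from compound 1 to compound 3 (0.26 log units; within the scatter) shows what exchanging an aryl for an arylamino on the carbonyl carbon did, and compound 4 reverses exactly that exchange. The step of a 1.0-fold lower number from compound 2 to compound 3 (0.02 log units; within the scatter) shows that altering the halogen pattern on the aryl ring made no difference beyond the scatter, which also covers the added chlorine in compound 4. Compound 4 is therefore expected to land close to compound 1, a modest upward step of a 1.6-fold higher number from compound 3 to compound 4 (0.19 log units; within the scatter) in this assay, itself within the scatter. For compound 4 the estimate is 1400 nM, with a range from 700 nM to 2800 nM.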

Compound 4, concentration for 50% growth inhibition: 6140 nM
Beside the measured number, compound 4's estimate is 4.4-fold (0.64 log units) below it; measured number above the stated range.
By their numbers in this assay, from the lowest: compounds 3, 2 and 1 (each within the scatter of the next); then compound 4.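

In this assay, going by these compounds alone, chloro in place of hydrogen on an aromatic carbon gives a 3.7-fold higher number from compound 1 to compound 4 (0.57 log units; beyond the scatter), the first single-group change here whose step lies beyond the scatter. The earlier change to the aryl ring, a 1.0-fold lower number from compound 2 to compound 3 (0.02 log units; within the scatter), stayed within the scatter, so this ring is not indifferent to substitution in every setting. With the chloro present, the arylamino groups on the carbonyl carbon also separate from the aryl group that replaces them, as a 6.9-fold higher number from compound 3 to compound 4 (0.84 log units; beyond the scatter) and a 6.6-fold higher number from compound 2 to compound 4 (0.82 log units; beyond the scatter) show, whereas without it a 1.8-fold lower number from compound 1 to compound 3 (0.26 log units; within the scatter) stayed within the scatter.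

Nothing available explains why the chloro has this effect. Going by these compounds, it remains open whether fluoro, methyl or methoxy on that aromatic carbon would bring a similar rise, and whether chloro is tolerated there only when the arylamino group is present.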